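The source may report more compounds than this note shows. Statements on the series, on what has been measured and on what is new or still open speak of the compounds shown alone.

Compound 2 `Cc1cc(C(=O)Nc2ccc(S(=O)(=O)N3CCCC3)cc2)n(C)n1` stands at the edge of what an ADME assay on Vero cells (Chlorocebus sabaeus) for cytotoxicity, read by MTT assay (a lower number here means that less compound is tolerated, a higher number that more compound is tolerated), can report: in this assay compound 2 gives > 300000 nM, which is a limit rather than a number, as the limit of > 300000 nM in this assay, at which 1 of the 2 values shown sits, shows. Among the compounds with values here, compound 1 `O=C(Nc1ccc(S(=O)(=O)N2CCCC2)cc1)c1ccc(Br)cc1` differs from it only at the carbonyl carbon, and in this assay compound 1 gives 59000 nM; the single measured step is an at least 5.0-fold higher number from compound 1 to compound 2 (0.70 log units; beyond the scatter). Compound 3 `Cn1nc(C(C)(C)C)cc1C(=O)Nc1ccc(S(=O)(=O)N2CCCC2)cc1` carries tert-butyl in place of methyl on an aromatic carbon. Within the data shown here, no measured step bears on such a change, so no step beyond the scatter is expected, a number no higher from compound 2 to compound 3 (the limit leaves the size open). Compound 3 is therefore estimated at 300000 nM, between 100000 nM and 600000 nM.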

Compound 3, half-maximal cytotoxic concentration: 140000 nM
The estimate for compound 3 lay 2.1-fold (0.33 log units) above the measured number, and the stated range covers the measured number.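

In this assay, tert-butyl in place of methyl on this aromatic carbon gives an at least 2.1-fold lower number from compound 2 to compound 3 (0.33 log units; beyond the scatter). The earlier step concerned only the group on the carbonyl carbon, whereas this one shows that a change on the five-membered aromatic ring itself also moves the number. The full size of the step stays open, as the value of compound 2 is a limit: the limit of > 300000 nM in this assay, at which 1 of the 3 values shown sits.

The compounds shown leave open where an ethyl or isopropyl group at this carbon would fall between methyl and tert-butyl. They also leave open how an amine or a carboxylic acid there would read.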